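Cyclohexyl for Thiophenyl at the Chain End

The source may hold more compounds than are shown below. What is called first, only, known or untested is meant among the compounds shown, and "the series" means these compounds.

In an assay on HEK293 cells for inhibition of N-acylethanolamine-hydrolyzing acid amidase (Rattus norvegicus), read by LC-MS, with a stated time of 30 min (on this read-out higher numbers stand for weaker inhibition and lower numbers for stronger inhibition), compound 1 `O=C(CCCCCCc1ccccc1)N1CCCC1` gives 12900 nM and compound 2 `O=C(CCCCCCc1cccs1)N1CCCC1` gives 14100 nM. For the measured compounds named here, compound 2 holds the highest of the two numbers, with compound 1 as its only neighbour; the step of a 1.1-fold higher number from compound 1 to compound 2 (0.04 log units; within the scatter) shows that these two stand within the scatter of each other, so no order between them can be claimed. Compound 3 `O=C(CCCCCCC1CCCCC1)N1CCCC1` carries the change (cyclohexyl in place of thiophen-2-yl on a saturated chain carbon, six bonds along the chain from a carbonyl carbon). Going by the values given here, the only step so far, a 1.1-fold higher number from compound 1 to compound 2 (0.04 log units; within the scatter), exchanges one aromatic ring for another and does not reach the saturated ring that enters here, so there is no measured step that bears directly on this change. Compound 3 is therefore expected to show a step of a 1.0-fold lower number from compound 2 to compound 3 (0.00 log units; within the scatter) that stays within the scatter. Compound 3 is estimated at 14000 nM, with a range from 5000 nM to 40000 nM.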

Compound 3, half-maximal inhibitory concentration: 5700 nM
Estimate against measurement, compound 3: 2.5-fold (0.39 log units) above; the measured number falls inside the stated range.
By their numbers in this assay, from the lowest: compound 3; then compounds 1 and 2 (each within the scatter of the next).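

For the compounds shown here, on a saturated chain carbon, six bonds along the chain from a carbonyl carbon, exchanging one aromatic ring for another had left no readable difference in this assay, but the saturated ring gives the first step beyond the scatter at this position (a 2.5-fold lower number from compound 2 to compound 3 (0.39 log units; beyond the scatter)). The comparison with the phenyl ring points the same way (a 2.3-fold lower number from compound 1 to compound 3 (0.35 log units; beyond the scatter)), so cyclohexyl separates from both aromatic rings shown, though both steps are modest. Nothing available explains why the saturated ring goes with the lower number.

The compounds shown leave open whether cyclopentyl, or a piperidine ring with its ring amine, would keep the lower number at this position. They also leave open whether the step from the aromatic rings to cyclohexyl would persist on a longer chain.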